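The source may report more compounds than this note shows. Statements on the series, on what has been measured and on what is new or still open speak of the compounds shown alone.

Among the compounds with values here, the three compounds measured so far share one core and differ only in the group on the sulfur. Compound 1 `CC(C)c1n[nH]c2c(NCc3ccc(-c4ccccn4)cc3)nc(SCC3CNC(=O)O3)nc12` carries (2-oxo-1,3-oxazolidin-5-yl)methyl there, and in a functional assay on HT cells (Homo sapiens) for antiproliferative activity, read by fluorescence, with a stated time of 72 h (on this read-out higher numbers stand for weaker inhibition of growth and lower numbers for stronger inhibition of growth), compound 1 gives 80 nM. Compound 2 `CC(C)c1n[nH]c2c(NCc3ccc(-c4ccccn4)cc3)nc(SCCNC(=N)N)nc12` gives 390 nM, a step described as a 4.9-fold higher number from compound 1 to compound 2 (0.69 log units; beyond the scatter). Compound 3 `CC(C)c1n[nH]c2c(NCc3ccc(-c4ccccn4)cc3)nc(SC3CCCC3O)nc12`, with 2-hydroxycyclopentyl on the sulfur, gives 567 nM; it has the highest number of the three, with a 7.1-fold higher number from compound 1 to compound 3 (0.85 log units; beyond the scatter) and a 1.5-fold higher number from compound 2 to compound 3 (0.16 log units; within the scatter).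

Compound 4 `C=CCSc1nc(NCc2ccc(-c3ccccn3)cc2)c2[nH]nc(C(C)C)c2n1` is the next step from compound 3: allyl in place of 2-hydroxycyclopentyl on a sulfur. Within the data shown here, no measured step exchanges a ring-bearing group for a short open chain without donors or acceptors, so the two steps onto the sulfur that exist are the only guide, and they show that this position tolerates considerable variation, within the limits set by compound 1 at one end and compound 3 at the other. Compound 4 is therefore expected to land near compound 3, with a 1.4-fold higher number from compound 3 to compound 4 (0.15 log units; within the scatter) as the estimated step, and an estimate for compound 4 of 800 nM, between 250 nM and 2500 nM.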

Compound 4, concentration for 50% growth inhibition: 1010 nM
Estimate against measurement, compound 4: 1.3-fold (0.10 log units) below, and the stated range covers the measured number.
By their numbers in this assay, from the lowest: compound 1; then compounds 2, 3 and 4 (each within the scatter of the next, the first and the last beyond it).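

In this assay, allyl on the sulfur, with no ring and no hydrogen-bond donor or acceptor, cannot be told apart from 2-hydroxycyclopentyl (a 1.8-fold higher number from compound 3 to compound 4 (0.25 log units; within the scatter)), so this exchange of the ring and its hydroxyl for a short open chain shows no effect beyond the scatter. The same allyl does separate from the group of compound 2 (a 2.6-fold higher number from compound 2 to compound 4 (0.41 log units; beyond the scatter)) and far more clearly from (2-oxo-1,3-oxazolidin-5-yl)methyl (a 13-fold higher number from compound 1 to compound 4 (1.10 log units; beyond the scatter)), the largest step seen on this sulfur, which leaves compound 1 apart from the other three. No measurement given here accounts for these differences.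

The compounds shown leave open where a plain amine, a carboxylic acid or a longer saturated chain on the sulfur would fall. They also leave open whether the low number of compound 1 needs the 2-oxo-1,3-oxazolidin-5-yl ring or would persist with an open-chain amide.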